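Swapping chloro for methoxy on the pendant aryl ring

The source may report more compounds than this note shows. Statements on the series, on what has been measured and on what is new or still open speak of the compounds shown alone.

Of the compounds shown here, three sharing one core have been measured in a functional assay on MDA-MB-231 cells (Homo sapiens) for inhibition; a higher number here means a weaker inhibitor of growth, a lower number a stronger inhibitor of growth. Compound 1 `COc1cc(/C=C/C(=O)c2cccc(-n3cc(-c4ccc(Cl)cc4)[nH]c3=O)c2)cc(OC)c1OC` gives 13800 nM, the highest of the three numbers. Compound 2 `COc1cc(/C=C/C(=O)c2cccc(-n3cc(-c4ccccc4)[nH]c3=O)c2)ccc1O` gives 3360 nM in this assay, and compound 3 `O=C(/C=C/c1cccc(O)c1)c1cccc(-n2cc(-c3ccc(Cl)cc3)[nH]c2=O)c1` gives 3350 nM in this assay; each of these numbers is lower than that of compound 1 by more than the usual scatter. Compound 4 `COc1ccc(-c2cn(-c3cccc(C(=O)/C=C/c4cc(OC)c(OC)c(OC)c4)c3)c(=O)[nH]2)cc1` is not yet measured. It differs from compound 1 in one place: methoxy in place of chloro on an aromatic carbon. Among the measured compounds shown here, no measured pair shows this exact change, so its effect is unknown. In this assay the step from compound 1 to compound 4 is expected to be small, a 1.7-fold lower number from compound 1 to compound 4 (0.24 log units; within the scatter), perhaps towards a slightly lower number. Compound 4 is estimated at 8000 nM in this assay, within a range of 2500 nM to 25000 nM.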

Compound 4, concentration for 50% growth inhibition: 5480 nM
The estimate for compound 4 lay 1.5-fold (0.16 log units) above the measured number; low and high end bracket the measured number.
By their numbers in this assay, from the lowest: compounds 3, 2 and 4 (each within the scatter of the next); then compound 1.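

In this assay, going from 4-chlorophenyl to 4-methoxyphenyl gives a 2.5-fold lower number from compound 1 to compound 4 (0.40 log units; beyond the scatter) and is a modest step. Among the compounds shown here, this is the first direct sign that the group on this aromatic carbon, para to a large group, affects growth inhibition on the core of compound 1. Nothing at hand explains the step.

An amine or a carboxylic acid at this position remains untested among the compounds shown, so it is unclear how far the number can move here. Also open, as far as these compounds go, is whether the same swap would give a similar step in compound 3, whose other aryl ring differs.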